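The compounds below may be only part of what the source reports. "The series", "measured", "known", "first", "only" and "open" are said of these compounds alone.

Measured so far:
compound 1 `COc1cc(NC(C)CCCNC(=O)Nc2cc(C(F)(F)F)cc(C(F)(F)F)c2)c2ncccc2c1` — 4100 nM
compound 2 `COc1cc(NC(C)CCCNC(=O)Nc2cccc(C(F)(F)F)c2)c2ncccc2c1` — 19000 nM
compound 3 `COc1cc(NC(C)CCCNC(=O)NNC(=O)Nc2cccc(C(F)(F)F)c2)c2ncccc2c1` — 6900 nM

All three were tested in a functional assay on CCRF-CEM cells (Homo sapiens) for inhibition, read by MTT assay, with a stated time of 72 h; on this read-out higher numbers stand for weaker inhibition and lower numbers for stronger inhibition. Compound 1 and compound 2 share one core, and the only difference between them is trifluoromethyl in place of hydrogen on an aromatic carbon. That change gave a 4.6-fold lower number from compound 2 to compound 1 (0.67 log units; beyond the scatter). Compound 3 carries a different core; how the core of compound 3 differs from the core of compound 2 is not broken down here. In this assay compound 3 gives 6900 nM, which sits between the values of compound 2 and compound 1.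

Compound 4 `COc1cc(NC(C)CCCNC(=O)NNC(=O)Nc2cc(C(F)(F)F)cc(C(F)(F)F)c2)c2ncccc2c1` has not yet been measured. It differs from compound 3 by trifluoromethyl in place of hydrogen on an aromatic carbon, and the place described for this change is the same, word for word, as the place of the change from compound 2 to compound 1, so it is the same change made on the core of compound 3. Because of a 4.6-fold lower number from compound 2 to compound 1 (0.67 log units; beyond the scatter), the step from compound 3 to compound 4 in this assay is expected to be of about the same size, around a 3.8-fold lower number from compound 3 to compound 4 (0.58 log units; beyond the scatter), with some allowance for the different core. Compound 4 is therefore estimated at 1800 nM, most likely between 700 nM and 5000 nM.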

Compound 4, half-maximal inhibitory concentration: 13000 nM
For compound 4 the middle estimate is 7.2-fold (0.86 log units) below the measured one; measured number above the stated range.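

In this assay, the same addition of trifluoromethyl gave a 1.9-fold higher number from compound 3 to compound 4 (0.28 log units; within the scatter), so the clear gain seen on the core of compound 1 did not appear on the core of compound 3. Set side by side, the two steps differ by more than repeated measurement would account for, which shows that in these compounds the result of this change did not carry from one core to the other: the same change on two cores in this assay, a 4.6-fold lower number (0.67 log units; beyond the scatter) from compound 2 to compound 1 and a 1.9-fold higher number (0.28 log units; within the scatter) from compound 3 to compound 4, 8.7-fold (0.94 log units) apart, beyond the scatter of two such steps This rests on only two pairs of compounds, and it does not show which part of the cores matters or why, nor, with a step within the scatter, whether the change has any real effect on the core of compound 3.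

The compounds shown leave open whether other groups, such as a chlorine atom or a nitrile, in place of the same hydrogen would also behave differently on the two cores. They also leave open whether the split between the cores would persist with a longer chain in place of the present one.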